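Compound 2 and the Fluoro Group It Loses

A few compounds are considered here, and "the series" means these few. Any claim that something is new, unique, unknown or untested is made for them only; others in the source may bear on it.

Of the compounds shown here, two built on closely related structures have been tested in a functional assay on PC-3 cells (Homo sapiens) for antiproliferative activity, read by MTT assay, with a stated time of 72 h; a lower number here means a stronger inhibitor, a higher number a weaker inhibitor. Compound 1 (`O=C(N/N=C/c1cccc(Cl)c1Cl)Nc1ccc(Oc2ccnc3[nH]ccc23)cc1`) is reported as "not active" (no number reported), with no number attached. Compound 2 (`CN(C)CCn1cccc1/C=N/NC(=O)Nc1ccc(Oc2ccnc3[nH]ccc23)c(F)c1`) gives 1600 nM. Going by the values given here, that is the only number available, so compound 2 has no numerical neighbour to be ranked against, and the single further entry, for compound 1, offers no figure.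

Compound 3 (`CN(C)CCn1cccc1/C=N/NC(=O)Nc1ccc(Oc2ccnc3[nH]ccc23)cc1`) has not yet been measured. It departs from compound 2 in one place, with hydrogen in place of fluoro on an aromatic carbon. Among the compounds with values here, no two measured compounds differ in one place only, and the data therefore give no direct measure of this change. The expectation has only compound 2 at 1600 nM as its anchor, and no shift beyond the usual scatter is expected in this assay, in either direction. The estimate is a 1.1-fold higher number from compound 2 to compound 3 (0.05 log units; within the scatter), a step expected to stay within that scatter. For compound 3 the expected value is 1800 nM, with an estimated range from 600 nM to 5500 nM.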

Compound 3, half-maximal inhibitory concentration: 3930 nM
Compound 3: middle estimate off by 2.2-fold (0.34 log units), on the low side; low and high end bracket the measured number.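

The fluoro group, which sits ortho to a large group and meta to a large group, now has its first direct reading: in this assay, hydrogen in its place gives a 2.5-fold higher number from compound 2 to compound 3 (0.39 log units; beyond the scatter) on an otherwise unchanged structure. This position therefore registers in this assay even when only one heavy atom, a fluorine, leaves and no ring, hydrogen-bond donor, hydrogen-bond acceptor or net charge is involved, and within this pair the fluoro compound, compound 2, is the stronger inhibitor, though only by a modest step. No evidence on the cause of this step is available.

The compounds shown leave open how a chloro, methyl or methoxy group would compare with fluoro and hydrogen on this same aromatic carbon. On these data alone, the step also rests on a single pair carrying the same side chain, and whether the exchange of fluoro for hydrogen gives a similar step when a morpholine or a longer chain replaces the dimethylamino group remains unknown.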